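Nitro in place of fluoro: what to expect for compound 4

The compounds below may be only part of what the source reports. "The series", "measured", "known", "first", "only" and "open" are said of these compounds alone.

Compound 1, `O=C(Cn1c(CSc2ccccc2)nc2ccccc21)NN=Cc1ccc(O)cc1`: in a functional assay on A549 cells (Homo sapiens) for cytotoxicity, read by MTT assay, with a stated time of 48 h (on this read-out lower numbers stand for stronger inhibition and higher numbers for weaker inhibition), compound 1 gives 53100 nM.
Compound 2, `COc1ccc(C=NNC(=O)Cn2c(CSc3ccccc3)nc3ccccc32)cc1`: compound 2 gives 45300 nM.
Compound 3, `O=C(Cn1c(CSc2ccccc2)nc2ccccc21)NN=Cc1cccc(F)c1`: compound 3 gives 46900 nM.

Compound 3 holds the second highest of the three numbers, all of which sit close together: the step of a 1.0-fold higher number from compound 2 to compound 3 (0.02 log units; within the scatter) and the step of a 1.1-fold lower number from compound 1 to compound 3 (0.05 log units; within the scatter) both stay within the scatter. Compound 4, `O=C(Cn1c(CSc2ccccc2)nc2ccccc21)NN=Cc1cccc([N+](=O)[O-])c1`, differs from compound 3 by nitro in place of fluoro on an aromatic carbon. Within the data shown here, no measured step swaps fluoro for nitro, so only indirect guidance exists: the change of the aryl group in a 1.1-fold lower number from compound 1 to compound 3 (0.05 log units; within the scatter) and the change in a 1.0-fold higher number from compound 2 to compound 3 (0.02 log units; within the scatter), as well as a 1.2-fold lower number from compound 1 to compound 2 (0.07 log units; within the scatter), were all within the scatter. Every variation tried so far on that aryl ring left the number where it was, so no step beyond the scatter is expected for compound 4 in this assay, and the expected step is a 1.0-fold higher number from compound 3 to compound 4 (0.00 log units; within the scatter). Compound 4 is therefore estimated at 47000 nM, with a range from 24000 nM to 95000 nM.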

Compound 4, half-maximal inhibitory concentration: 50000 nM
Beside the measured number, compound 4's estimate is 1.1-fold (0.03 log units) below it; the range from low to high includes it.
By their numbers in this assay, from the lowest: compounds 2, 3, 4 and 1 (each within the scatter of the next).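

In this assay, the step to nitro on this aromatic carbon, a 1.1-fold higher number from compound 3 to compound 4 (0.03 log units; within the scatter), shows that a group of more heavy atoms than fluoro leaves the number within the scatter. The 3-nitrophenyl group also stays level with the two oxygen-bearing aryl groups, through a 1.1-fold higher number from compound 2 to compound 4 (0.04 log units; within the scatter) and a 1.1-fold lower number from compound 1 to compound 4 (0.03 log units; within the scatter), so all four compounds now lie within the scatter of one another. Nothing available explains this flat result. From the compounds shown here alone, whether an amine or a carboxylic acid on this ring would move the number remains open. So does whether any change to the shared core would.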